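The source may report more compounds than this note shows. Statements on the series, on what has been measured and on what is new or still open speak of the compounds shown alone.

Two compounds of this series have a number in a functional assay on HeLa cells for antagonist activity at 5-hydroxytryptamine receptor 6 (Homo sapiens), read by cAMP accumulation, with stated times of 10 min and 30 min (a lower number here means a stronger inhibitor, a higher number a weaker inhibitor), so far. Compound 1 `Cc1ccc(N2CCc3c(NS(=O)(=O)c4ccc(F)cc4)n[nH]c3C2=O)cc1` gives 5220 nM. For the measured compounds named here, compound 2 `Cc1ccc(N2CCc3c(NS(=O)(=O)c4cccc(C(F)(F)F)c4)n[nH]c3C2=O)cc1` gives 3280 nM, the lower of the two numbers; the single step between them, a 1.6-fold lower number from compound 1 to compound 2 (0.20 log units; within the scatter), lies within the scatter, so compound 2 cannot be called the stronger inhibitor on these data. Compound 3 `COc1cccc(S(=O)(=O)Nc2n[nH]c3c2CCN(c2ccc(C)cc2)C3=O)c1` has not yet been measured. It differs from compound 2 in one place: methoxy in place of trifluoromethyl on an aromatic carbon. Going by the values given here, the only measured step that bears on this change is a 1.6-fold lower number from compound 1 to compound 2 (0.20 log units; within the scatter), which also exchanged the aryl ring on the sulfonyl sulfur and produced no movement beyond the scatter. Among the compounds with values here, no measured compound carries a methoxy on this ring, so the data give no ground for expecting a move beyond the scatter in either direction in this assay. Compound 3 is therefore estimated to give about 3500 nM in this assay, with an expected range from 1200 nM to 10000 nM. The expected step from compound 2 is a 1.1-fold higher number from compound 2 to compound 3 (0.03 log units; within the scatter), essentially flat.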

Compound 3, half-maximal inhibitory concentration: 6770 nM
The estimate for compound 3 lay 1.9-fold (0.29 log units) below the measured number, and the stated range covers the measured number.
By their numbers in this assay, from the lowest: compounds 2, 1 and 3 (each within the scatter of the next, the first and the last beyond it).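

In this assay, exchanging trifluoromethyl for methoxy on this aromatic carbon, meta to a large group, gives a 2.1-fold higher number from compound 2 to compound 3 (0.31 log units; beyond the scatter), the only step among these compounds that lies beyond the scatter, and only modestly so. The group at this carbon can therefore shift the number to a small degree, with 3-(trifluoromethyl)phenyl giving the lower number of this pair, whereas the earlier step between aryl rings on the sulfonyl sulfur could not show any shift. For the compounds shown here, the comparison with the other ring gives a 1.3-fold higher number from compound 1 to compound 3 (0.11 log units; within the scatter), so compound 3 cannot be separated from compound 1, and the single step beyond the scatter rests on one pair; nothing available accounts for the difference between the two groups.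

From the compounds shown here alone, it remains open whether a hydroxyl, an amine or a carboxylic acid on this aromatic carbon would move the number further in either direction, or whether a group could bring it well below the values seen here. Also open, going by these compounds, is whether methoxy on another carbon of this ring would give a number different from that of compound 3.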